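A trifluoromethyl swap on a shared core

The compounds below may be only part of what the source reports. "The series", "measured", "known", "first", "only" and "open" are said of these compounds alone.

Compound 1 `COc1ccc2ccc(=O)oc2c1C1=NNC(c2ccc(C)cc2)C1` gives 43 nM in a functional assay on HepG2 cells (Homo sapiens) for cytotoxicity, read by MTT assay, with a stated time of 72 h; on this read-out lower numbers stand for stronger inhibition and higher numbers for weaker inhibition.
Compound 2 `COc1ccc2ccc(=O)oc2c1C(/C=C/c1ccccc1)=N/NC(N)=O` gives 82 nM in this assay.
Compound 3 `COc1ccc2ccc(=O)oc2c1C1=NN(C(C)=O)C(c2ccc(SC)cc2)C1` gives 42 nM in this assay.

Among these three, compound 3 shows the lowest number in this assay, but its gap to compound 1 and its gap to compound 2 both fall within the usual scatter, so no order among the three can be read from the numbers. Compound 4 `COc1ccc2ccc(=O)oc2c1C1=NN(C(C)=O)C(c2ccc(C(F)(F)F)cc2)C1` differs from compound 3 in one place: trifluoromethyl in place of methylsulfanyl on an aromatic carbon. For the measured compounds named here, no two measured compounds differ in only one place, so no measured step speaks to this change. The step is expected to remain within the scatter, with no clear direction. Compound 4 is estimated at 55 nM, within a range from 20 nM to 150 nM. This amounts to an expected step of a 1.3-fold higher number from compound 3 to compound 4 (0.12 log units; within the scatter).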

Compound 4, half-maximal inhibitory concentration: 80 nM
Compound 4: middle estimate off by 1.5-fold (0.16 log units), on the low side; low and high end bracket the measured number.
By their numbers in this assay, from the lowest: compounds 3, 1, 4 and 2 (each within the scatter of the next).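

In this assay, trifluoromethyl in place of methylsulfanyl on an aromatic carbon gives a 1.9-fold higher number from compound 3 to compound 4 (0.28 log units; within the scatter), the first single-place step measured in this series. At this position, para to a large group, the two groups therefore cannot be told apart on this read-out. No evidence is available on what lies behind this result.

Going by these compounds, it remains open whether an amine, a carboxylic acid or a longer chain at this position would give a step beyond the scatter. For the compounds shown here, with only this one step, no trend across groups at this position can be drawn.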